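Working notes: ring-nitrogen substituent change, compound 3 to compound 4

The compounds below may be only part of what the source reports. "The series", "measured", "known", "first", "only" and "open" are said of these compounds alone.

Measured compounds:
compound 1, `CCCCCCCCn1cc(Cn2c(CC)nc3nc(C(F)(F)F)ccc3c2=O)nn1`, in a functional assay on PANC-1 cells (Homo sapiens) for antiproliferative activity, read by sulforhodamine B assay, with a stated time of 48 h; a lower number here means a stronger inhibitor of growth, a higher number a weaker inhibitor of growth: 3280 nM
compound 2, `CCc1nc2nc(C(F)(F)F)ccc2c(=O)n1Cc1cn(CCC(F)(F)C(F)(F)C(F)(F)C(F)(F)C(F)(F)C(F)(F)F)nn1`, in this assay: 730 nM
compound 3, `O=C(Cn1cc(COc2nc(-c3ccccc3)nc3nc(C(F)(F)F)ccc23)nn1)Nc1ccccc1`, in this assay: 4500 nM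

Compound 3 holds the highest number of the three. Its gap to compound 1 is within the scatter, so no order between the two can be read; its gap to compound 2 lies beyond the scatter, compound 2 having the lower number.

Compound 4, `COc1cc(-n2cc(COc3nc(-c4ccccc4)nc4nc(C(F)(F)F)ccc34)nn2)cc(OC)c1OC`, differs from compound 3 in one place: 3,4,5-trimethoxyphenyl in place of (phenylcarbamoyl)methyl on an aromatic nitrogen. For the measured compounds named here, no measured pair shows a step of this kind, so there is no reference step to lean on. A modest step toward a lower number is expected, of about a 1.8-fold lower number from compound 3 to compound 4 (0.26 log units; within the scatter), a size not clearly beyond the scatter. Compound 4 is estimated at 2500 nM in this assay, with a range from 500 nM to 12000 nM.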

Compound 4, concentration for 50% growth inhibition: 820 nM
The estimate for compound 4 lay 3.0-fold (0.48 log units) above the measured number; measured number inside the range.
By their numbers in this assay, from the lowest: compounds 2 and 4 (each within the scatter of the next); then compounds 1 and 3 (each within the scatter of the next).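

In this assay, the group on the aromatic nitrogen of the five-membered ring proves able to shift the number: 3,4,5-trimethoxyphenyl in place of (phenylcarbamoyl)methyl gives a 5.5-fold lower number from compound 3 to compound 4 (0.74 log units; beyond the scatter). The shared core and the rest of the molecule stay unchanged across this pair, so the step belongs to this one exchange. No available measurement accounts for the step.

Open, going by these compounds, is whether the three methoxy groups are needed, which an unsubstituted phenyl or a single-methoxy phenyl at this nitrogen would test. Also open, on these data alone, is whether the exchange carries over to the core of compound 1.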